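Capping One Phosphate of a Bisphosphate Purine Antagonist

The compounds below may be only part of what the source reports. "The series", "measured", "known", "first", "only" and "open" are said of these compounds alone.

Measured compounds and their numbers:
Compound 1, `CNc1nc(Cl)nc2c1ncn2CCC(COP(=O)(O)O)COP(=O)(O)O`, gives 840 nM.
Compound 2, `CNc1ncnc2c1ncn2CC(COP(=O)(O)O)COP(=O)(O)O`, gives 1090 nM.
Compound 3, `CNc1nc(Cl)nc2c1ncn2CC(COP(=O)(O)O)COP(=O)(O)O`, gives 480 nM.

All three were tested in an assay on cell membranes for inhibition of P2Y purinoceptor 1 (Meleagris gallopavo); a higher number here means a weaker inhibitor, a lower number a stronger inhibitor. The three compounds share a purine core carrying two phosphate groups on a short chain. Compound 3 has the lowest number of the three. Its nearest neighbour is compound 1, whose number is higher but within the scatter, so the two cannot be told apart. Against compound 2 the gap is beyond the scatter: a 2.3-fold lower number from compound 2 to compound 3 (0.36 log units; beyond the scatter), a modest step that comes with chloro in place of hydrogen on an aromatic carbon.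

Compound 4, `CNc1nc(Cl)nc2c1ncn2CC(COP(=O)(O)O)COP(=O)(OC)OC`, has not yet been measured in this assay. It differs from compound 3 in one place: a group of 6 heavy atoms (2 carbon, 3 oxygen, 1 phosphorus; no ring) in place of a group of 4 heavy atoms (3 oxygen, 1 phosphorus; no ring), on an oxygen on a saturated carbon. Among the measured compounds shown here, the only measured step, from compound 2 to compound 3, concerns the aromatic ring and not the phosphate end of the chain, so no measured step bears on this change. The measured data give no guide here, and the estimate is correspondingly uncertain. Compound 4 is expected to give a somewhat higher number, an estimated 3000 nM with a range from 800 nM to 15000 nM, meaning an expected step of a 6.3-fold higher number from compound 3 to compound 4 (0.80 log units; beyond the scatter).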

Compound 4, half-maximal inhibitory concentration: 31000 nM
Compound 4: the middle estimate sits 10-fold (1.01 log units) below what was measured; measured number above the stated range.
By their numbers in this assay, from the lowest: compounds 3, 1 and 2 (each within the scatter of the next, the first and the last beyond it); then compound 4.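

At the phosphate end of the chain, this assay shows a 65-fold higher number from compound 3 to compound 4 (1.81 log units; beyond the scatter) when a group of 6 heavy atoms replaces a group of 4 heavy atoms on an oxygen on a saturated carbon, far more than a 2.3-fold lower number from compound 2 to compound 3 (0.36 log units; beyond the scatter) that came with chloro on the aromatic carbon. So this end of the molecule tolerates change much less well than the one aromatic position tried so far, and keeping the second phosphate intact does not preserve the activity of compound 3. The change adds 2 carbon atoms and takes the group from 2 hydrogen-bond donors to 0, but nothing available shows which of these differences matters or why the number climbs so steeply.

From the compounds shown here alone, it remains open whether a phosphate carrying just one methyl group, or a carboxylic acid in the same place, would stay closer to compound 3 or fall as far as compound 4. It is also unknown whether the same change would cost as much on the longer chain of compound 1, or on compound 2, which has hydrogen in place of chloro.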